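The source may hold more compounds than are shown below. What is called first, only, known or untested is meant among the compounds shown, and "the series" means these compounds.

Measured so far:
- compound 1 `CN(C)c1nc2c(ncn2-c2ccccc2)c(=O)n1-c1ccccc1`: in a functional assay on HepG2 cells (Homo sapiens) for cytotoxicity, read by MTT assay, with a stated time of 72 h (a lower number here means a stronger inhibitor, a higher number a weaker inhibitor), compound 1 gives > 100000 nM, which is a limit of the assay and not a number.
- compound 2 `CCCCCN(CCCCC)c1nc2c(ncn2-c2ccccc2)c(=O)n1-c1ccc(Cl)cc1`: in this assay compound 2 gives > 100000 nM, likewise a limit of the assay.

Among the measured compounds shown here, compound 1 thus stands at the limit without a number of its own, and the only other value stands in the same place, as both values sit at the limit of > 100000 nM in this assay, at which 2 of the 2 values shown sit. For the measured compounds named here, no step between measured compounds can be read here, so the series gives no measured step size to lean on.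

The change from compound 1 to compound 3 `CNc1nc2c(ncn2-c2ccccc2)c(=O)n1-c1ccccc1` is hydrogen in place of methyl on a nitrogen on an aromatic ring; cut one bond further out, it reads dimethylamino to methylamino. With both measured values at the limit, compound 3 is expected to remain at the limit as well, the step that the limit leaves unreadable from compound 1 to compound 3 being expected as none beyond the scatter. For compound 3 the estimate in this assay is 150000 nM, with a range from 30000 nM to 1000000 nM.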

Compound 3, half-maximal inhibitory concentration: > 100000 nM
Compound 3: no number, only a limit; the forecaster's own chance of this, stated with the estimate: 80%; the middle value does not contradict the limit.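

Compound 1 and compound 3 both stand at a limit of this assay and not at a number, so no step can be read between them. The compounds shown leave open whether any change on the shared core gives a measurable value in this assay.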